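Phenyl to 4-fluorophenyl on compound 2

This account rests on a few compounds, and the source may have more. Where it says the series, first, only, none or still open, it means among the compounds named here.

In a functional assay on MCF7 cells (Homo sapiens) for inhibition, read by MTT assay, with a stated time of 48 h (a higher number here means a weaker inhibitor of growth, a lower number a stronger inhibitor of growth), compound 1 `COc1ccc2c(c1)c(C1CC(c3ccccc3)=NN1C(=O)c1cccnc1)cn2C` gives 1160 nM and compound 2 `COc1ccc2c(c1)c(C1CC(c3ccccc3)=NN1C(=O)c1ccc(OC)nc1)cn2C` gives 990 nM, so the two stand within the scatter of each other. Compound 3 `COc1ccc2c(c1)c(C1CC(c3ccc(F)cc3)=NN1C(=O)c1ccc(OC)nc1)cn2C` differs from compound 2 by fluoro in place of hydrogen on an aromatic carbon. For the measured compounds named here, only one measured step bears on this, and only loosely, since it is a different substituent: a 1.2-fold lower number from compound 1 to compound 2 (0.07 log units; within the scatter), within the scatter. No step beyond the scatter is therefore expected in this assay. The estimate amounts to an expected 1.1-fold lower number from compound 2 to compound 3 (0.05 log units; within the scatter). For compound 3 the expected value is 880 nM, with an estimated range of 380 nM to 2000 nM.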

Compound 3, concentration for 50% growth inhibition: 480 nM
The estimate for compound 3 lay 1.8-fold (0.26 log units) above the measured number, within the range that was stated.
By their numbers in this assay, from the lowest: compound 3; then compounds 2 and 1 (each within the scatter of the next).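

Phenyl to 4-fluorophenyl moves the number in this assay beyond the scatter, with a 2.1-fold lower number from compound 2 to compound 3 (0.31 log units; beyond the scatter) as a modest step, whereas a 1.2-fold lower number from compound 1 to compound 2 (0.07 log units; within the scatter) does not leave it. This position, para to a large group, therefore responds to a single fluoro atom in this assay, the only such response among the steps shown. Nothing measured on these compounds accounts for the step.

From the compounds shown here alone, whether the response is specific to fluoro remains open, as chloro, methoxy or an amine at this position would show. Going by these compounds, whether fluoro gives a comparable step on compound 1 also remains open.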